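Removing a methyl from a pyridazine core: expected effect

A few compounds are considered here, and "the series" means these few. Any claim that something is new, unique, unknown or untested is made for them only; others in the source may bear on it.

Three hydrazone compounds have been tested in a functional assay on HeLa cells (Homo sapiens) for antiproliferative activity, read by sulforhodamine B assay; a higher number here means a weaker inhibitor, a lower number a stronger inhibitor. Compound 1 `C/C(=N\Nc1nc2ccccc2o1)c1nccnc1C` gives 1860 nM. Compound 2 `C/C(=N\Nc1nc2ccccc2o1)c1cnccn1` gives 690 nM. The difference between them is hydrogen in place of methyl on an aromatic carbon, and this change produced a 2.7-fold lower number from compound 1 to compound 2 (0.43 log units; beyond the scatter). Compound 3 `C/C(=N\Nc1nc2ccccc2o1)c1ccc(C)nn1` gives 3390 nM; how its core differs from that of compound 1 is not broken down here.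

Compound 4 `C/C(=N\Nc1nc2ccccc2o1)c1cccnn1` has not yet been measured. It differs from compound 3 by hydrogen in place of methyl on an aromatic carbon. Among the compounds with values here, this is the same kind of change as the one from compound 1 to compound 2, but not the same: in compound 1 the methyl stands ortho to a large group, whereas in compound 3 it stands para to a large group.

Because the step of a 2.7-fold lower number from compound 1 to compound 2 (0.43 log units; beyond the scatter) was modest, a step of roughly similar size is expected here, and compound 4 is estimated at 1500 nM, between 600 nM and 4000 nM. Within the data shown here, this estimate means an expected step of a 2.3-fold lower number from compound 3 to compound 4 (0.35 log units; beyond the scatter) in this assay, resting on the single earlier example alone.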

Compound 4, half-maximal inhibitory concentration: 1180 nM
Estimate against measurement, compound 4: 1.3-fold (0.10 log units) above; the measured number falls inside the stated range.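

In this assay, replacing the methyl with hydrogen on a second core gave a 2.9-fold lower number from compound 3 to compound 4 (0.46 log units; beyond the scatter), and this step matches the earlier one: the same change on two cores in this assay, a 2.7-fold lower number (0.43 log units; beyond the scatter) from compound 1 to compound 2 and a 2.9-fold lower number (0.46 log units; beyond the scatter) from compound 3 to compound 4, 1.1-fold (0.03 log units) apart, within the scatter of two such steps

Across these two pairs, then, the change carries from one core to the other with much the same size, but two pairs cannot show that it would do so on every core, and the numbers alone do not explain why it lowers the value. Once the methyl is gone, exchanging the ring itself, pyridazin-3-yl in place of pyrazin-2-yl, gives a 1.7-fold higher number from compound 2 to compound 4 (0.23 log units; within the scatter), so compound 2 and compound 4 cannot be told apart here.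

As far as these compounds go, only methyl and hydrogen appear at these positions, so it remains open how an ethyl group, a methoxy group, a chlorine atom or an amine would behave there. From the compounds shown here alone, whether the same step would appear on a core with a third arrangement of ring atoms also remains open.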